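The source may report more compounds than this note shows. Statements on the series, on what has been measured and on what is new or still open speak of the compounds shown alone.

Measured in a functional assay on HUVEC cells (Homo sapiens) for inhibition, with a stated time of 4 days; on this read-out lower numbers stand for stronger inhibition and higher numbers for weaker inhibition:
- compound 1 `Cc1cc(OCc2cccc(C#N)c2)ccc1Cl`: 11000 nM
- compound 2 `CCc1ccc(OC)c(COc2ccc(Cl)c(C)c2)c1`: 40000 nM
- compound 3 `COc1ccc(C(N)=O)cc1COc1ccc(Cl)cc1`: 660 nM

Compound 2 has the highest number of the three, so it is the weakest inhibitor so far, with compound 1 nearest at 11000 nM and compound 3 furthest at 660 nM. Compound 4 `COC(=O)c1ccc(OC)c(COc2ccc(Cl)c(C)c2)c1` carries methoxycarbonyl in place of ethyl on an aromatic carbon, para to a methoxy group (methoxycarbonyl in place of ethyl on an aromatic carbon). Among the compounds with values here, no single-place step has been measured. Compound 3, at 660 nM, also carries a carbonyl, but it differs from compound 2 in more than one place, so this support is weak. In this assay the estimated step is a 6.7-fold lower number from compound 2 to compound 4 (0.82 log units; beyond the scatter), a moderate move towards stronger inhibition, expected to lie beyond the scatter. For compound 4 the expected value is 6000 nM, with an estimated range of 1500 nM to 25000 nM.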

Compound 4, half-maximal inhibitory concentration: 2300 nM
The estimate for compound 4 lay 2.6-fold (0.42 log units) above the measured number, within the range that was stated.
By their numbers in this assay, from the lowest: compound 3; then compound 4; then compound 1; then compound 2.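

In this assay, within the data shown here, the aromatic carbon para to a methoxy group proves sensitive to its substituent: methoxycarbonyl in place of ethyl gives a 17-fold lower number from compound 2 to compound 4 (1.24 log units; beyond the scatter), the only single-place step. The entering group brings hydrogen-bond acceptors and no donor, so a large gain at this place does not require a hydrogen-bond donor. No available evidence accounts for the gain. As far as these compounds go, whether a carboxylic acid on this carbon would match or exceed methoxycarbonyl remains open. So does whether a longer ester, such as ethoxycarbonyl, would keep the gain.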